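Swapping fluoro for chloro on a second core

A few compounds are considered here, and "the series" means these few. Any claim that something is new, unique, unknown or untested is made for them only; others in the source may bear on it.

In a functional assay on HT-29 cells (Homo sapiens) for antiproliferative activity, read by MTT assay, with a stated time of 72 h (a higher number here means a weaker inhibitor, a lower number a stronger inhibitor), compound 1, whose structure is `O=C(Nc1ccc(Oc2ccnc3[nH]ccc23)c(F)c1)c1cc2cccnc2n(-c2ccc(F)cc2)c1=O`, gives 36 nM. Compound 2, with structure `O=C(Nc1ccc(Oc2ccnc3[nH]ccc23)c(F)c1)c1cc2cccnc2n(-c2ccc(Cl)cc2)c1=O`, differs from compound 1 by one change, (chloro in place of fluoro on an aromatic carbon), and in this assay compound 2 gives 82 nM. That change produced a 2.3-fold higher number from compound 1 to compound 2 (0.36 log units; beyond the scatter), so the chloro analogue is the weaker inhibitor of the two.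

Compound 3, whose structure is `Cn1ccc2c(Oc3ccc(NC(=O)c4cc5cccnc5n(-c5ccc(F)cc5)c4=O)cc3)ccnc21`, carries a different core; the difference between the two cores is not broken down here. In this assay compound 3 gives 250 nM, the highest of the three measured numbers, standing beyond the scatter above both compound 1 and compound 2.

Compound 4, with structure `Cn1ccc2c(Oc3ccc(NC(=O)c4cc5cccnc5n(-c5ccc(Cl)cc5)c4=O)cc3)ccnc21`, has not yet been measured. Within the data shown here, it differs from compound 3 by chloro in place of fluoro on an aromatic carbon, which is the same change, at the same kind of place, as the one that separates compound 1 from compound 2. Among the measured compounds shown here, on that single precedent the expectation is that compound 4 will again be somewhat weaker than compound 3, with a step of about a 2.2-fold higher number from compound 3 to compound 4 (0.34 log units; beyond the scatter), because the one measured example of this change gave a 2.3-fold higher number from compound 1 to compound 2 (0.36 log units; beyond the scatter). For the measured compounds named here, the estimate for compound 4 in this assay is therefore 550 nM, with a likely range from 250 nM to 1200 nM, the range being wide since only one measured pair supports it and the core of compound 3 differs from that of compound 1.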

Compound 4, half-maximal inhibitory concentration: 730 nM
Compound 4: the middle estimate sits 1.3-fold (0.12 log units) below what was measured; the range from low to high includes it.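

In this assay, moving from the 4-fluorophenyl to the 4-chlorophenyl group on the second core gives a 2.9-fold higher number from compound 3 to compound 4 (0.47 log units; beyond the scatter), so the chloro compound is again the weaker inhibitor of its pair. The change therefore carries over from one core to the other, in the same direction and to a similar size: the same change on two cores in this assay, a 2.3-fold higher number (0.36 log units; beyond the scatter) from compound 1 to compound 2 and a 2.9-fold higher number (0.47 log units; beyond the scatter) from compound 3 to compound 4, 1.3-fold (0.11 log units) apart, within the scatter of two such steps. Among these compounds, this is still only two matched pairs in a single cell assay, so it does not show that the step would hold on a third core or in a different test, and it does not explain why chloro gives the weaker inhibitor on either core.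

The compounds shown leave open how other groups at this same place on the aromatic ring would compare on either core, such as a bromo, a methyl, a methoxy or simply a hydrogen. They also leave open which part of the difference between the core of compound 1 and the core of compound 3 matters for activity, since no pair shown isolates a single change between those two cores.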